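This account rests on a few compounds, and the source may have more. Where it says the series, first, only, none or still open, it means among the compounds named here.

Compound 1 `COc1ccc(C2=C(c3cn(C)c4ccccc34)C(=O)OC2)cc1OC` gives 1000 nM in a functional assay on U-937 cells (Homo sapiens) for cytotoxicity, read by MTT assay; on this read-out lower numbers stand for stronger inhibition and higher numbers for weaker inhibition.
Compound 2 `CCOC(=O)n1cc(C2=C(c3ccc(OC)c(OC)c3)COC2=O)c2ccccc21` gives 300 nM in this assay.

Of these two numbers compound 2 holds the lower one, and the gap to compound 1 lies beyond the scatter. Among the measured compounds shown here, the single measured step, a 3.3-fold lower number from compound 1 to compound 2 (0.52 log units; beyond the scatter), comes from an ethoxycarbonyl in place of methyl on the aromatic nitrogen. Compound 3 `COc1ccc(C2=C(c3c[nH]c4ccccc34)C(=O)OC2)cc1OC` changes the same nitrogen once more: hydrogen in place of ethoxycarbonyl on an aromatic nitrogen. For the measured compounds named here, no measured pair covers this exact change, so the only guide is the earlier step, which it reverses in part by removing the group whose arrival gave a 3.3-fold lower number from compound 1 to compound 2 (0.52 log units; beyond the scatter). The number is therefore expected to move back up, toward that of compound 1. The expected step is a 2.7-fold higher number from compound 2 to compound 3 (0.43 log units; beyond the scatter). This rests on one step alone, so the range is wide. Compound 3 is expected to give 800 nM in this assay, between 300 nM and 2500 nM.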

Compound 3, half-maximal inhibitory concentration: 9000 nM
Compound 3: middle estimate off by 11-fold (1.05 log units), on the low side, outside the stated range (above it).
By their numbers in this assay, from the lowest: compound 2; then compound 1; then compound 3.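

Hydrogen on this aromatic nitrogen gives the highest number of the three in this assay, so removing the ethoxycarbonyl does not simply return the value to that of the methyl compound. The loss is large, with a 30-fold higher number from compound 2 to compound 3 (1.48 log units; beyond the scatter) and a smaller but still clear rise of a 9.0-fold higher number from compound 1 to compound 3 (0.95 log units; beyond the scatter) when hydrogen replaces methyl. Across these three compounds, both groups on the nitrogen go with a lower number than hydrogen, and the earlier gain of a 3.3-fold lower number from compound 1 to compound 2 (0.52 log units; beyond the scatter) proves smaller than the gap separating methyl from hydrogen.

The compounds shown leave open how a longer chain such as propyl, or an acetyl or benzyl group, would behave on this nitrogen. No available evidence explains why these numbers move as they do.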